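This account rests on a few compounds, and the source may have more. Where it says the series, first, only, none or still open, it means among the compounds named here.

Compound 1 `CCc1ccc(N(CC(C)C)S(=O)(=O)c2ccc3c(c2)C(O)CC(C2CCOCC2)O3)cc1` and compound 2 `O=S(=O)(c1ccc2c(c1)C(O)CC(C1CCOCC1)O2)N1CCCC1c1ccccc1C(F)(F)F` share one core and differ in what is attached through the sulfonyl sulfur. In an ADME assay on liver (Homo sapiens) for metabolic stability, read by LC-MS, with a stated time of 30 min (a higher number here means faster removal of the compound, a lower number slower removal), compound 1 gives 330 mL/min/kg and compound 2 gives 172 mL/min/kg. These two numbers lie within the usual scatter of repeated measurements, so compound 1 cannot be set apart from compound 2 on this evidence.

Compound 3 `CC(C)CN(c1cc2ccccc2s1)S(=O)(=O)c1ccc2c(c1)C(O)CC(C1CCOCC1)O2` is compound 1 with 1-benzothiophen-2-yl in place of 4-ethylphenyl on a sulfonamide nitrogen. Going by the values given here, no measured pair shows this swap alone, so the data give no direct size for it. Among the compounds with values here, the only guide is indirect: with different groups in that part of the molecule, compound 1 at 330 mL/min/kg and compound 2 at 172 mL/min/kg stay within the scatter of each other. In this assay, therefore, no step beyond the scatter is expected, in either direction. The expected change is a 1.2-fold lower number from compound 1 to compound 3 (0.07 log units; within the scatter), an estimated step too small to stand out from repeat measurements. For compound 3 the estimated clearance is 280 mL/min/kg, with an expected range from 130 mL/min/kg to 600 mL/min/kg.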

Compound 3, clearance: 53.7 mL/min/kg
Compound 3: middle estimate off by 5.2-fold (0.72 log units), on the high side, outside the stated range (below it).
By their numbers in this assay, from the lowest: compound 3; then compounds 2 and 1 (each within the scatter of the next).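

Compound 3 shows that the group on the sulfonamide nitrogen can matter in this assay: with the rest of the molecule unchanged, putting 1-benzothiophen-2-yl in place of 4-ethylphenyl gives a 6.1-fold lower number from compound 1 to compound 3 (0.79 log units; beyond the scatter). Going by these compounds alone, this is the first single-group change whose effect can be read, and it stands clear of the differences expected between repeat measurements, which compound 1 and compound 2 alone could not show. The data offer no measured explanation for this drop in clearance.

The swap changes several things at once: the ethyl chain leaves, a five-membered aromatic ring with sulfur enters, and the group gains one heavy atom, so this one step cannot say which of these changes matters. A plain phenyl or a 1-benzofuran-2-yl group, which has oxygen in place of the sulfur, on the same sulfonamide nitrogen would help to separate these possibilities, while a longer chain in place of the saturated chain on that nitrogen would test whether the step holds in a changed setting.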